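Methyl on the Pyridine Ring: From Compound 1 to Compound 3

The compounds below may be only part of what the source reports. "The series", "measured", "known", "first", "only" and "open" are said of these compounds alone.

Measured so far:
Compound 1 `N/C(=N\NC(=S)N1CCCCCC1)c1ccccn1` — 6000 nM
Compound 2 `Cc1ccnc(/C(N)=N/NC(=S)N2CCN(c3ccccn3)CC2)c1` — 10500 nM

Both compounds were tested in a functional assay on HeLa cells (Homo sapiens) for cytotoxicity, read by MTT assay, with a stated time of 72 h; a higher number here means a weaker inhibitor, a lower number a stronger inhibitor. Compound 1 gives 6000 nM, and compound 2 gives 10500 nM. Of the two numbers shown, compound 1 has the lower one, yet the two values lie within the usual scatter of each other, so no order can be read from them. The two structures differ in more than one place, so the pair does not isolate a single change.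

Compound 3 `Cc1ccnc(/C(N)=N/NC(=S)N2CCCCCC2)c1` has not yet been measured in this assay. It differs from compound 1 in one place: methyl in place of hydrogen on an aromatic carbon. The step from compound 1 to compound 3 is thus a small addition, a methyl group entering on the aromatic ring, leaving the thiourea and the seven-membered amine ring of the shared core untouched.

Among the measured compounds shown here, no measured pair shows this change on its own. Compound 3 is expected to give about 7000 nM in this assay, with a range from 3000 nM to 16000 nM. This estimate means an expected step of a 1.2-fold higher number from compound 1 to compound 3 (0.07 log units; within the scatter), one that should stay within the scatter rather than move the number clearly in either direction.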

Compound 3, half-maximal inhibitory concentration: 7000 nM
The estimate for compound 3 equals the measured number at the digits printed; the measured number falls inside the stated range.
By their numbers in this assay, from the lowest: compounds 1, 3 and 2 (each within the scatter of the next).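

Among the compounds shown here, compound 3 gives the first reading of a single change: in this assay, methyl in place of hydrogen on an aromatic carbon, opposite the ring nitrogen, gives a 1.2-fold higher number from compound 1 to compound 3 (0.07 log units; within the scatter) on the core of compound 1. At this position, then, a methyl group leaves the number without a readable shift, something the earlier pair could not show, as its two structures differ in more than one place. Nothing measured here speaks to why the number holds.

As far as these compounds go, a single small group says little about the position as a whole, so it remains open whether an amine, a carboxylic acid or a longer chain there would shift the number clearly. Also open, from the compounds shown here alone, is whether methyl elsewhere on the same ring would behave alike.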